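Fluoro in place of methoxy: from compound 2 to compound 3

A few compounds are considered here, and "the series" means these few. Any claim that something is new, unique, unknown or untested is made for them only; others in the source may bear on it.

Measured so far:
compound 1 `N#C/C(=C\c1cn(Cc2ccc(Cl)cc2)c2ccccc12)C(=O)c1c[nH]c2ccccc12`: > 50000 nM, a limit of the assay
compound 2 `COc1ccc2c(/C=C(\C#N)C(=O)c3c[nH]c4cc(OC)ccc34)c[nH]c2c1`: 1700 nM

Going by the values given here, in a functional assay on A549 cells (Homo sapiens) for cytotoxicity, read by WST assay, with a stated time of 48 h (on this read-out higher numbers stand for weaker inhibition and lower numbers for stronger inhibition), compound 2 gives 1700 nM, the only numerical value in the set. Compound 1 gives only a limit, > 50000 nM. The evidence here is the limit of > 50000 nM in this assay, at which 1 of the 2 values shown sits.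

Compound 3 `COc1ccc2c(C(=O)/C(C#N)=C/c3c[nH]c4cc(F)ccc34)c[nH]c2c1` differs from compound 2 by fluoro in place of methoxy on an aromatic carbon. Among the compounds with values here, no measured step covers such a change, so the expectation rests on compound 2 alone; the step of a 1.5-fold higher number from compound 2 to compound 3 (0.17 log units; within the scatter) is expected to be small, toward weaker inhibition or within the scatter. Compound 3 is estimated at 2500 nM, within 800 nM to 8000 nM.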

Compound 3, half-maximal inhibitory concentration: 800 nM
Estimate against measurement, compound 3: 3.1-fold (0.49 log units) above; low and high end bracket the measured number.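

In this assay, the methoxy on this aromatic carbon proves dispensable for cytotoxicity: fluoro in its place gives a 2.1-fold lower number from compound 2 to compound 3 (0.33 log units; beyond the scatter) and the activity is kept, with the number moving toward stronger inhibition. Going by these compounds alone, this is the first single-place change, and it shows that this position responds to substitution. Nothing measured here accounts for the step.

Whether the trend is specific to fluoro stays open, as chloro, hydroxyl or an amine on this carbon are not among the compounds shown. On these data alone, the effect of the same change on the remaining methoxy also stays open.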